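Working notes: one bromine removed from compound 1

The compounds below may be only part of what the source reports. "The series", "measured", "known", "first", "only" and "open" are said of these compounds alone.

Compound 1 `O=C(Nc1ccc(Sc2nc3ccccc3s2)cc1)c1cc(Br)cc(Br)c1O` is the reference point of this small set. Going by the values given here, in an ADME assay on HEK293 cells (Homo sapiens) for cytotoxicity, read by resazurin assay, with a stated time of 48 h (a higher number here means that more compound is tolerated, a lower number that less compound is tolerated), compound 1 gives 69000 nM, the highest of the three numbers measured so far. Compound 3 `O=S(=O)(Nc1ccc(-c2nc3cc(NS(=O)(=O)c4ccc(Cl)s4)ccc3o2)cc1)c1ccc(Cl)c(C(F)(F)F)c1` gives 34000 nM in this assay, and compound 2 `COc1ccc(S(=O)(=O)Nc2ccc3oc(-c4ccc(NS(=O)(=O)c5cc(Br)ccc5OC)cc4)nc3c2)cc1` gives 18000 nM; both numbers lie below that of compound 1 by more than the usual scatter. Compound 4 `O=C(Nc1ccc(Sc2nc3ccccc3s2)cc1)c1cccc(Br)c1O` has not yet been measured; it differs from compound 1 by hydrogen in place of bromo on an aromatic carbon. Among the compounds with values here, no measured pair shows this same change, so the expected step rests on compound 1 alone. The step from compound 1 to compound 4 is expected to be small, a 1.2-fold higher number from compound 1 to compound 4 (0.06 log units; within the scatter), likely within the scatter rather than a clear shift in either direction. Compound 4 is therefore estimated at 80000 nM, with a range of 35000 nM to 180000 nM.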

Compound 4, half-maximal cytotoxic concentration: 33000 nM
For compound 4 the middle estimate is 2.4-fold (0.38 log units) above the measured one; the measured number lies below the stated range.
By their numbers in this assay, from the lowest: compounds 2, 4 and 3 (each within the scatter of the next); then compound 1.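

Going by these compounds alone, replacing the bromo group para to the hydroxy group gives the first step that can be read at a single position: in this assay, 3,5-dibromo-2-hydroxyphenyl to 3-bromo-2-hydroxyphenyl gives a 2.1-fold lower number from compound 1 to compound 4 (0.32 log units; beyond the scatter). This position therefore affects the read-out, with less compound tolerated when hydrogen replaces bromo. No available data bear on the origin of this step.

Going by these compounds, whether chloro, methyl or an amine at this position would align with compound 1 or compound 4 remains open. Also open, on these data alone, is whether removing the remaining bromo group would produce a step in the same direction.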